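Clearance notes: bromo in place of methyl

This account rests on a few compounds, and the source may have more. Where it says the series, first, only, none or still open, it means among the compounds named here.

Among the measured compounds shown here, in an in vitro ADME assay on microsomes from liver (Mus musculus) for pharmacokinetics, read by LC-MS (on this read-out higher numbers stand for fast clearance and lower numbers for slow clearance), compound 1 `Cc1cccc2c1nc(C)n2-c1ccc(C(=O)NC2CC2)s1` gives 66 mL/min/kg, the only actual number so far. Compound 2 `Cc1cccc2nc(C)n(-c3ccc(C(=O)NC4CC4)s3)c12` reports only a limit, > 72 mL/min/kg. Compound 3 `Cc1nc2cc(C(F)(F)F)ccc2n1-c1ccc(C(=O)NC2CC2)s1` also reports only a limit, > 72 mL/min/kg.

Compound 4 `Cc1nc2c(Br)cccc2n1-c1ccc(C(=O)NC2CC2)s1` departs from compound 1 by one change: bromo in place of methyl on an aromatic carbon. For the measured compounds named here, no measured step covers this change, so the expectation starts from compound 1 at 66 mL/min/kg, and no shift beyond the usual scatter is expected in this assay, in either direction. The expected step, a 1.1-fold lower number from compound 1 to compound 4 (0.04 log units; within the scatter), is estimated to stay within that scatter. For compound 4 the estimated clearance is 60 mL/min/kg, with an expected range of 35 mL/min/kg to 95 mL/min/kg.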

Compound 4, clearance: 26 mL/min/kg
For compound 4 the middle estimate is 2.3-fold (0.36 log units) above the measured one, and the stated range ends above it.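

Bromo in place of methyl on an aromatic carbon gives a 2.5-fold lower number from compound 1 to compound 4 (0.40 log units; beyond the scatter) in this assay. Among the compounds shown here, this is the first readable step, and it shows that clearance at this position responds to this exchange beyond the usual scatter. Compound 2 and compound 3 give no readable step: the limit of > 72 mL/min/kg in this assay, at which 2 of the 4 values shown sit.

On these data alone, whether the lower number comes from bromo itself or from the loss of methyl stays open. So does whether chloro, methoxy or an amine at this position would shift clearance the same way.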